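Enantiomer Switch at the Ring Stereocentre in Rats

A few compounds are considered here, and "the series" means these few. Any claim that something is new, unique, unknown or untested is made for them only; others in the source may bear on it.

The measured compounds and their results in a functional assay on the whole organism with Rattus norvegicus as the target (on this read-out lower numbers stand for an effect already at smaller amounts and higher numbers for an effect only at larger amounts of compound), are:
compound 1, `CC1CCC(/C=N/c2ccccc2O)=C2NC=C(C(=O)O)C(=O)N21`, gives 4.11 umol/kg;
compound 2, `Cc1cccc(/N=C/C2=C3NC=C(C(=O)O)C(=O)N3C(C)CC2)c1`, gives 0.8 umol/kg;
compound 3, `Cc1cccc(/N=C/C2=C3NC=C(C(=O)O)C(=O)N3[C@@H](C)CC2)c1`, gives 0.02 umol/kg.

Compound 3 stands lowest of the three numbers in this assay. Its nearest neighbour is compound 2, and the step runs as a 40-fold lower number from compound 2 to compound 3 (1.60 log units; beyond the scatter); compound 1 lies furthest away, and the step from compound 1 to compound 2 is a 5.1-fold lower number from compound 1 to compound 2 (0.71 log units; beyond the scatter).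

The step now followed leads to compound 4, `Cc1cccc(/N=C/C2=C3NC=C(C(=O)O)C(=O)N3[C@H](C)CC2)c1`. Its difference from compound 3 is the two compounds have the same atoms and bonds and differ only in configuration as drawn: 1 of 2 stereo elements differ; a stereocentre at a saturated ring carbon is drawn S in compound 3 and R in compound 4.

Going by the values given here, only one measured step bears on this change, namely a 40-fold lower number from compound 2 to compound 3 (1.60 log units; beyond the scatter), and it rests on the fact that one of compounds 2 and 3 is drawn with a defined configuration and the other without, at the place where they differ: compound 2 carries no configuration at that centre while compound 3 is drawn as the S form. That the S form alone gives a far lower number than the undefined form points to the R form being the weaker one. A large step toward a higher number is therefore expected for compound 4 in this assay, reversing the gain seen from compound 2 to compound 3 and possibly going past it.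

For compound 4 the estimate is 5 umol/kg, with a range from 1 umol/kg to 30 umol/kg, meaning an expected step of a 250-fold higher number from compound 3 to compound 4 (2.40 log units; beyond the scatter).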

Compound 4, dose for 50% inhibition: 66.9 umol/kg
Compound 4: the middle estimate sits 13-fold (1.13 log units) below what was measured; measured number above the stated range.
By their numbers in this assay, from the lowest: compound 3; then compound 2; then compound 1; then compound 4.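

In this assay the two defined forms at the stereocentre on the saturated ring carbon can now be set directly against each other, and the result is a 3300-fold higher number from compound 3 to compound 4 (3.52 log units; beyond the scatter), which places the low number firmly with the S form and not merely with a defined configuration. Compound 2, drawn without a configuration at that centre, lies apart from both defined forms, and the R form sits further from it than the S form does, with an 84-fold higher number from compound 2 to compound 4 (1.92 log units; beyond the scatter). Since no atom or bond changes, the whole of this gap traces to the one centre: the fact that compounds 3 and 4 differ only in the configuration as drawn.

The compounds shown leave open whether the same preference for the S form holds with the 2-hydroxyphenyl group on the double-bonded nitrogen, as compound 1 is drawn without a configuration at that centre. Also open, from the compounds shown here alone, is how the two forms would compare with an ethyl group in place of the methyl at the stereocentre, and a whole-organism read-out of this kind does not by itself tell where in the animal the gap between the forms arises.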